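Compound 3 and the cytotoxicity limit

A few compounds are considered here, and "the series" means these few. Any claim that something is new, unique, unknown or untested is made for them only; others in the source may bear on it.

In an ADME assay on HEK293 cells (Homo sapiens) for cytotoxicity, with a stated time of 6 h (a higher number here means that more compound is tolerated, a lower number that less compound is tolerated), compound 1 (`CCCCNc1nc(N)nc2cccc(CCc3ccccc3)c12`) gives > 25000 nM as a limit and not a number. Compound 2 (`CCCCNc1nc(N)nc2cccc(OCc3ccccc3OC)c12`) gives > 25000 nM in this assay as a limit and not a number too. Among the compounds with values here, compound 2 thus stands on the limit of > 25000 nM in this assay, at which 2 of the 2 values shown sit, and no measured step is available for comparison.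

Compound 3 (`CCCCNc1nc(N)nc2cccc(OCc3cccnc3)c12`) differs from compound 2 by one change (pyridin-3-yl in place of 2-methoxyphenyl on a saturated chain carbon bound to an oxygen on an aromatic ring), with pyridin-3-yl in place of 2-methoxyphenyl on a saturated chain carbon bound to an oxygen on an aromatic ring. The expectation rests on compound 2 with > 25000 nM as its limit: no shift beyond the usual scatter is expected in either direction, and another limit is the likeliest result. The expected step is a step that the limit leaves unreadable from compound 2 to compound 3 and remains a rough estimate. In this assay the estimated half-maximal cytotoxic concentration for compound 3 is 30000 nM (range 15000 nM to 60000 nM).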

Compound 3, half-maximal cytotoxic concentration: > 25000 nM
Compound 3 ended at the assay's limit; the forecaster's own chance of this, stated with the estimate: 80%; the middle value is on the limit's open side.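

No step can be read from compound 2 to compound 3 or from compound 1 to compound 3 in this assay, because each of the three compounds gives only a limit: the limit of > 25000 nM in this assay, at which 3 of the 3 values shown sit.

The compounds shown leave open whether these groups on the shared core differ at all in half-maximal cytotoxic concentration.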